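The compounds below may be only part of what the source reports. "The series", "measured", "known", "first", "only" and "open" are said of these compounds alone.

Measured so far:
- compound 1 `CCCSc1nc(N/N=C(\C)c2ccccc2O)c2nnn(Cc3ccco3)c2n1`: 4760 nM
- compound 2 `C#CCSc1nc(N/N=C/c2cc(OC)c(OC)c(OC)c2)c2nnn(Cc3ccccc3)c2n1`: 4670 nM

In a functional assay on MGC-803 cells (Homo sapiens) for antiproliferative activity, read by MTT assay, with a stated time of 72 h (on this read-out lower numbers stand for stronger inhibition and higher numbers for weaker inhibition), compound 1 gives 4760 nM, the higher of the two numbers in hand. Compound 2 gives 4670 nM, which lies within the usual scatter of that, so the two compounds cannot be told apart on this read-out.

Compound 3 `CCCSc1nc(N/N=C(\C)c2ccccc2O)c2nnn(Cc3ccccc3)c2n1` has not yet been measured. It differs from compound 1 in a single place: phenyl in place of furan-2-yl on a saturated chain carbon bound to an aromatic nitrogen. Among the compounds with values here, no measured pair shows this change alone, so there is no directly comparable step. Compound 2 carries the benzyl group but also differs from compound 1 elsewhere; the value of compound 2, 4670 nM, sits close to that of compound 1. The step of a 1.1-fold lower number from compound 1 to compound 3 (0.05 log units; within the scatter) is therefore expected to be small, with no direction beyond the scatter. Compound 3 is expected to give about 4200 nM, with a likely range from 1500 nM to 11000 nM.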

Compound 3, half-maximal inhibitory concentration: 2310 nM
Compound 3: middle estimate off by 1.8-fold (0.26 log units), on the high side, within the range that was stated.
By their numbers in this assay, from the lowest: compound 3; then compounds 2 and 1 (each within the scatter of the next).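

In this assay, replacing furan-2-yl with phenyl on a saturated chain carbon bound to an aromatic nitrogen gives a 2.1-fold lower number from compound 1 to compound 3 (0.31 log units; beyond the scatter). Within the data shown here, this pair is the first to isolate a change at this position, and it shows that the position is not indifferent to its ring: swapping a five-membered aromatic ring with one hetero atom for a six-membered aromatic ring of carbon only moves the number modestly, just past the usual scatter. No measurement in hand says why the number moves.

On these data alone, whether this position needs an aromatic ring at all remains open, since a cyclohexylmethyl group or a plain butyl chain could show. As far as these compounds go, it is also open whether the same swap would give a similar step on a different remainder of the molecule, such as that of compound 2.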